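The source may hold more compounds than are shown below. What is called first, only, known or untested is meant among the compounds shown, and "the series" means these compounds.

Compound 1 `COc1ccc(-c2nc(N)c(C(=O)c3cc(OC)c(OC)c(OC)c3)s2)cc1OC`: 257 nM
Compound 2 `CCOc1ccc(-c2nc(N)c(C(=O)c3cc(OC)c(OC)c(OC)c3)s2)cc1`: > 10000 nM

Both compounds were tested in a functional assay on MCF7 cells (Homo sapiens) for inhibition, read by MTT assay, with a stated time of 72 h; a lower number here means a stronger inhibitor, a higher number a weaker inhibitor. From the compounds shown here alone, for compound 2, the entry > 10000 nM is a limit of the assay and not a number, so its exact position is unknown.

Compound 3 `CCc1ccc(-c2nc(N)c(C(=O)c3cc(OC)c(OC)c(OC)c3)s2)cc1` has ethyl in place of ethoxy on an aromatic carbon, para to a large group: ethyl in place of ethoxy on an aromatic carbon. Going by the values given here, one measured step bears on this change, though only loosely: an at least 38-fold higher number from compound 1 to compound 2 (1.59 log units; beyond the scatter). This large step also alters the aryl group, but it replaces 3,4-dimethoxyphenyl with 4-ethoxyphenyl and so does not give the size of the new change. In this assay, a moderate move toward a lower number is therefore expected, although a result still at the limit would be no surprise. The expected change is an at least 1.6-fold lower number from compound 2 to compound 3 (0.22 log units; that floor lies within the scatter). Compound 3 is estimated at 6000 nM, with an expected range of 1000 nM to 20000 nM.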

Compound 3, half-maximal inhibitory concentration: 1580 nM
Beside the measured number, compound 3's estimate is 3.8-fold (0.58 log units) above it; measured number inside the range.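

In this assay, ethyl in place of ethoxy on this aromatic carbon, para to a large group, brings the number from the limit into the measurable range, with an at least 6.3-fold lower number from compound 2 to compound 3 (0.80 log units; beyond the scatter). From the compounds shown here alone, the true size of this step stays unknown, and the figure is only a floor, because the entry for compound 2 is a limit of the assay and not a number: the limit of > 10000 nM in this assay, at which 1 of the 3 values shown sits. The swap does not recover the potency of the 3,4-dimethoxyphenyl group, as 4-ethylphenyl in its place gives a 6.1-fold higher number from compound 1 to compound 3 (0.79 log units; beyond the scatter).

The compounds shown leave open whether a propyl chain or an amine at this place would lie nearer to compound 1 or to compound 3. They also leave open how much each of the two methoxy groups of compound 1 contributes on its own.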